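The source may hold more compounds than are shown below. What is called first, only, known or untested is meant among the compounds shown, and "the series" means these compounds.

Working notes on the series.

Compound 1 `Nc1c2c(=O)[nH]c(-c3ccccc3)cc2nn1-c1ccccc1` is the reference point. In an assay on isolated protein for inhibition of MAP kinase-activated protein kinase 2 (Homo sapiens), read by mobility shift assay, tested at 30 uM (on this read-out lower numbers stand for less inhibition and higher numbers for more inhibition at the one concentration tested (going by the name of the read-out)), compound 1 gives 2%, the lowest of the two numbers in hand, but its nearest neighbour, compound 2 `COc1ccc(-c2cc3nn(-c4ccccc4)c(N)c3c(=O)[nH]2)cc1`, lies within the usual scatter: in this assay compound 2 gives 7%. Going by the values given here, the only measured step, a number 5 percentage points higher from compound 1 to compound 2 (within the scatter), is a methoxy in place of hydrogen on an aromatic carbon and stays within the scatter, so the two measured values are treated as equal.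

Compound 3 `Nc1c2c(=O)[nH]c(-c3ccccc3)cc2nn1-c1ccccn1` differs from compound 1 by pyridin-2-yl in place of phenyl on an aromatic nitrogen. Among the compounds with values here, no measured pair touches the group on the aromatic nitrogen, so the one available step gives no direct guidance; it only shows that the core so far sits at the low end of the read-out without movement. The step of a number 3 percentage points higher from compound 1 to compound 3 (within the scatter) is therefore expected to be none beyond the scatter, in no particular direction. For compound 3 the estimate is 5%, with a range from 0% to 15%.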

Compound 3, a percentage reported as inhibition, at one concentration (the size of the read-out at that concentration, not a potency): 6%
For compound 3 the middle estimate is 1 percentage points below the measured one, within the range that was stated.
By their numbers in this assay, from the lowest: compounds 1, 3 and 2 (each within the scatter of the next).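

In this assay, going by these compounds alone, pyridin-2-yl in place of phenyl on the aromatic nitrogen gives a number 4 percentage points higher from compound 1 to compound 3 (within the scatter) as the first reading at this position. One ring nitrogen and one hydrogen-bond acceptor can thus enter at this place, at the same count of heavy atoms, without any change beyond the scatter, so compound 3 and compound 1 count as equal here. No measured evidence bears on the reason for this result.

The compounds shown leave open whether a group other than a six-membered aromatic ring on this nitrogen, such as methyl, a longer alkyl chain or cyclohexyl, would lift the read-out out of the scatter. Also open, on these data alone, is whether an amine or a carboxylic acid on the phenyl or pyridin-2-yl ring would do so.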